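The compounds below may be only part of what the source reports. "The series", "measured", "known", "first", "only" and "open" are said of these compounds alone.

Measured so far in a functional assay on the whole organism with Rattus norvegicus as the target, at a dose of 100 mg/kg; a lower number here means less inhibition, a higher number more inhibition at the dose given (going by the name of the read-out):
compound 1 `CC/N=C(/NC#N)NCCCCn1nc(-c2ccccc2)ccc1=O` gives 58.8%
compound 2 `N#CNC(=N)NCCCCn1nc(-c2ccccc2)ccc1=O` gives 61.2%

Compound 2 and compound 1 sit within the scatter of each other in this assay, so neither is set apart by the numbers at hand. For the measured compounds named here, the one step measured, a number 2.4 percentage points higher from compound 1 to compound 2 (within the scatter), exchanges the group on the amine nitrogen and produces no shift beyond the scatter.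

Compound 3 `C/N=C(\NC#N)NCCCCn1nc(-c2ccccc2)ccc1=O` is not yet measured. Its difference from compound 2: a group of 6 heavy atoms (3 carbon, 3 nitrogen; no ring) in place of a group of 5 heavy atoms (2 carbon, 3 nitrogen; no ring), on an amine nitrogen. The change sits at the same amine nitrogen that was varied between compound 1 and compound 2, and the entering group of 3 carbon and 3 nitrogen lies between the groups of compound 1 and compound 2 in size. Going by the values given here, the only step that bears on it, a number 2.4 percentage points higher from compound 1 to compound 2 (within the scatter), was within the scatter, so no step beyond the scatter is expected here either. The step expected from compound 2 to compound 3 is a number 1.2 percentage points lower from compound 2 to compound 3 (within the scatter). Compound 3 is therefore estimated at 60%, with a range of 48% to 72%. Two compounds give a thin basis, so the range is kept wide.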

Compound 3, a percentage reported as inhibition, in the whole organism at one dose (the size of the read-out at that dose, not a potency): 79%
For compound 3 the middle estimate is 19 percentage points below the measured one, and the stated range ends below it.
By their numbers in this assay, from the lowest: compounds 1 and 2 (each within the scatter of the next); then compound 3.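

Working notes on the amine nitrogen: in this assay this position now proves responsive to the group it carries, since the group of 6 heavy atoms gives a number 17.8 percentage points higher from compound 2 to compound 3 (beyond the scatter) and also a number 20.2 percentage points higher from compound 1 to compound 3 (beyond the scatter) against the group of 7 heavy atoms. The earlier pair had shown no separation, and the heavy-atom count alone does not order this set: the groups of 5 and 7 heavy atoms remain within the scatter of each other, while the group of 6 heavy atoms stands apart from both. No measurement at hand accounts for the gain at compound 3.

The compounds shown leave open whether the gain at compound 3 is confined to its group or would persist with a propyl group, a benzyl group or a morpholine ring on the same amine nitrogen. They also leave open whether it carries over to a shorter or longer chain in place of the saturated chain, and, with readings at one dose only, how the compounds would rank across other doses.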